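Moving a Chlorine Around a Pendant Phenyl Ring

This account rests on a few compounds, and the source may have more. Where it says the series, first, only, none or still open, it means among the compounds named here.

Compound 1 `Clc1cccc(-c2cc(-c3ccoc3)cc(-c3ccc(Cl)s3)n2)c1` carries a 3-chlorophenyl group and, in a functional assay on HeLa cells (Homo sapiens) for cytotoxicity, read by ELISA, with a stated time of 4 days (on this read-out higher numbers stand for weaker inhibition and lower numbers for stronger inhibition), compound 1 gives 23700 nM. Compound 2 `Clc1ccc(-c2cc(-c3ccoc3)cc(-c3ccc(Cl)s3)n2)cc1` differs only in that change (4-chlorophenyl in place of 3-chlorophenyl on an aromatic carbon), and in this assay compound 2 gives 16500 nM, a step of a 1.4-fold lower number from compound 1 to compound 2 (0.16 log units; within the scatter). Compound 3 `Cc1ccsc1-c1cc(-c2ccc(Cl)o2)cc(-c2cccc(Cl)c2)n1` has a different core; the difference between the two cores is not broken down here. In this assay compound 3 gives 24800 nM. Compound 4 `Cc1ccsc1-c1cc(-c2ccc(Cl)o2)cc(-c2ccc(Cl)cc2)n1` is related to compound 3 by the same kind of change, (4-chlorophenyl in place of 3-chlorophenyl on an aromatic carbon), though the surroundings differ: here the place is meta to a 3-methylthiophen-2-yl group and to a 5-chlorofuran-2-yl group, where in compound 1 it was meta to a 5-chlorothiophen-2-yl group and to a furan-3-yl group. Because the earlier step of a 1.4-fold lower number from compound 1 to compound 2 (0.16 log units; within the scatter) stayed within the scatter, a similarly small step is expected, a 1.4-fold lower number from compound 3 to compound 4 (0.14 log units; within the scatter). Compound 4 is therefore estimated at 18000 nM in this assay, between 9000 nM and 36000 nM.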

Compound 4, half-maximal inhibitory concentration: 29300 nM
Compound 4: the middle estimate sits 1.6-fold (0.21 log units) below what was measured; the range from low to high includes it.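

In this assay, putting 4-chlorophenyl in place of 3-chlorophenyl on the second core gives a 1.2-fold higher number from compound 3 to compound 4 (0.07 log units; within the scatter), so the two values cannot be told apart. Set beside the same change on the first core, the result shows no difference between the two cores: the same change on two cores in this assay, a 1.4-fold lower number (0.16 log units; within the scatter) from compound 1 to compound 2 and a 1.2-fold higher number (0.07 log units; within the scatter) from compound 3 to compound 4, 1.7-fold (0.23 log units) apart, within the scatter of two such steps

This shows that the change made no clear difference on either core, but neither step is large enough to give a real size or direction that could be carried from one core to another. The compounds shown leave open whether an amine or a carboxylic acid in place of the chlorine on this phenyl ring would give a step beyond the scatter, and whether such a step would then hold on both cores.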